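Methoxyphenyl in place of chlorophenyl on the triazole nitrogen

The source may hold more compounds than are shown below. What is called first, only, known or untested is meant among the compounds shown, and "the series" means these compounds.

In a functional assay on MCF7 cells (Homo sapiens) for antiproliferative activity, read by MTT assay, with a stated time of 48 h (a lower number here means a stronger inhibitor, a higher number a weaker inhibitor), the measured compounds stand as follows:
Compound 1 `N#CC1=C(N)Oc2c(c3nc4ccccc4nc3c3ccccc23)C12C(=O)N(Cc1cnnn1-c1ccc(Br)cc1)c1ccccc12` gives 36600 nM.
Compound 2 `N#CC1=C(N)Oc2c(c3nc4ccccc4nc3c3ccccc23)C12C(=O)N(Cc1cnnn1-c1ccc(Cl)c(Cl)c1)c1ccccc12` gives only a limit of the assay, > 50000 nM.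
Compound 3 `N#CC1=C(N)Oc2c(N)cc3nc4ccccc4nc3c2C12C(=O)N(Cc1cnnn1-c1ccc(Cl)cc1)c1ccccc12` gives only a limit of the assay, > 50000 nM.

Compound 3 thus has no number of its own in this assay; its value is one of the two that sit at the limit (the limit of > 50000 nM in this assay, at which 2 of the 3 values shown sit), so it is only known to be a weak inhibitor. Compound 4 `COc1ccccc1-n1nncc1CN1C(=O)C2(C(C#N)=C(N)Oc3c(N)cc4nc5ccccc5nc4c32)c2ccccc21` differs from compound 3 in a single place: 2-methoxyphenyl in place of 4-chlorophenyl on an aromatic nitrogen. For the measured compounds named here, only one measured step touches the same place, the swap on the aromatic nitrogen of the triazole from compound 1 to compound 2, and it gave an at least 1.3-fold higher number from compound 1 to compound 2 (0.13 log units; that floor lies within the scatter), a floor that lies within the scatter. That step offers no sign that changing the phenyl group on this nitrogen moves activity far in either direction. With compound 3 already at the limit, compound 4 is expected to remain a weak inhibitor, at or near the limit, and the step from compound 3 to compound 4 is estimated as a number no higher from compound 3 to compound 4 (the limit leaves the size open). Compound 4 is therefore estimated at 50000 nM, with a range from 15000 nM to 150000 nM.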

Compound 4, half-maximal inhibitory concentration: 28900 nM
The estimate for compound 4 lay 1.7-fold (0.24 log units) above the measured number; low and high end bracket the measured number.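

Swapping 4-chlorophenyl for 2-methoxyphenyl on the aromatic nitrogen of the triazole gives, in this assay, an at least 1.7-fold lower number from compound 3 to compound 4 (0.23 log units; that floor lies within the scatter). This shows that, on the core shared by compound 3 and compound 4, a change at this nitrogen can yield a measured number, although the printed floor alone does not establish a real gain. Compound 3 carries only a limit, which leaves the true size of the step open: the limit of > 50000 nM in this assay, at which 2 of the 4 values shown sit.

The two groups differ both in their substituent and in where it sits on the phenyl ring, so these compounds cannot show which of the two differences matters. Going by these compounds, how a plain phenyl or a butyl chain on this nitrogen would behave also remains open.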